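Methyl for Benzyl on a Selenium-Bearing Chain

The source may report more compounds than this note shows. Statements on the series, on what has been measured and on what is new or still open speak of the compounds shown alone.

The three measured compounds, all tested in a functional assay on PC-3 cells (Homo sapiens) for cytotoxicity, read by MTT assay, with a stated time of 72 h; on this read-out lower numbers stand for stronger inhibition of growth and higher numbers for weaker inhibition of growth:
Compound 1, `C[Se]/C(=N\C(=O)c1cc2ccccc2s1)NC(=O)c1cc2ccccc2s1`, gives 65600 nM.
Compound 2, `O=C(/N=C(/NC(=O)c1csc([N+](=O)[O-])c1)[Se]Cc1ccccc1)c1csc([N+](=O)[O-])c1`, gives 69200 nM.
Compound 3, `O=C(/N=C(/NC(=O)c1cc2ccccc2s1)[Se]Cc1ccccc1)c1cc2ccccc2s1`, gives 58400 nM.

Compound 3 and compound 1 share the same core and differ in a single spot: hydrogen in place of phenyl on a saturated chain carbon bound to a selenium atom. This change gave a 1.1-fold higher number from compound 3 to compound 1 (0.05 log units; within the scatter), so within this series the benzyl and methyl versions behave alike in this assay. Compound 2 carries a different core from compound 3; the difference between the two cores is not broken down here, and all three measured values sit close to one another in this assay.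

The unmeasured compound 4, `C[Se]/C(=N\C(=O)c1csc([N+](=O)[O-])c1)NC(=O)c1csc([N+](=O)[O-])c1`, is built from compound 2 by the same change seen between compound 3 and compound 1: hydrogen in place of phenyl on a saturated chain carbon bound to a selenium atom. Because the earlier instance gave a 1.1-fold higher number from compound 3 to compound 1 (0.05 log units; within the scatter), the step from compound 2 to compound 4 is expected to be small as well, estimated as a 1.1-fold higher number from compound 2 to compound 4 (0.03 log units; within the scatter). On that basis compound 4 is estimated at 74000 nM in this assay, with a likely range from 45000 nM to 125000 nM. The expectation rests on a single precedent on a different core, so the range is kept wide enough to allow for ordinary scatter in this kind of growth-inhibition read-out.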

Compound 4, concentration for total growth inhibition: 7090 nM
For compound 4 the middle estimate is 10-fold (1.02 log units) above the measured one; measured number below the stated range.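

On the core of compound 2, putting hydrogen in place of phenyl, which turns benzyl into methyl, is a real change in this assay: the step is a 9.8-fold lower number from compound 2 to compound 4 (0.99 log units; beyond the scatter), meaning that the methyl compound inhibits growth more strongly, while on the core of compound 3 the same swap gave a 1.1-fold higher number from compound 3 to compound 1 (0.05 log units; within the scatter). So this change does not carry over from one core to the other with the same size, and a newly measured step of this kind cannot simply be copied from its precedent, as the two steps side by side show: the same change on two cores in this assay, a 1.1-fold higher number (0.05 log units; within the scatter) from compound 3 to compound 1 and a 9.8-fold lower number (0.99 log units; beyond the scatter) from compound 2 to compound 4, 11-fold (1.04 log units) apart, beyond the scatter of two such steps What these two pairs do not show is which part of the cores is behind the gap, or why the methyl compound stands apart on only one of them, since each core offers a single step and nothing here separates those explanations.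

On these data alone, it remains open whether an ethyl group or a longer chain in place of methyl would keep the lower number of compound 4 or return towards that of compound 2. As far as these compounds go, it also remains open whether a third core would behave like the core of compound 2, like the core of compound 3, or like neither.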